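Hydroxy to methoxy on compound 1

The compounds below may be only part of what the source reports. "The series", "measured", "known", "first", "only" and "open" are said of these compounds alone.

Measured so far in a functional assay on SK-MEL-28 cells (Homo sapiens) for inhibition, read by sulforhodamine B assay, with a stated time of 48 h; on this read-out higher numbers stand for weaker inhibition of growth and lower numbers for stronger inhibition of growth

- compound 1 (`O=C(Nc1cccc(-n2cc(-c3ccncc3)c(-c3ccc(Cl)c(O)c3)n2)c1)Nc1cccc(C(F)(F)F)c1`): > 32500 nM
- compound 2 (`COc1cc(-c2nn(-c3cccc(NC(=O)Nc4ccc(Cl)c(Cl)c4)c3)cc2-c2ccncc2)ccc1Cl`): 7320 nM

Compound 1 gives only a limit in this assay and no number, and so stands at the limit of > 32500 nM in this assay, at which 1 of the 2 values shown sits. Compound 2, which carries a 4-chloro-3-methoxyphenyl group, gives a measured 7320 nM in the same read-out.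

Compound 3 (`COc1cc(-c2nn(-c3cccc(NC(=O)Nc4cccc(C(F)(F)F)c4)c3)cc2-c2ccncc2)ccc1Cl`) has not yet been measured. It differs from compound 1 by methyl in place of hydrogen on an oxygen on an aromatic ring, which is methyl in place of hydrogen on an oxygen on an aromatic ring, or hydroxy to methoxy.

Within the data shown here, no step between measured compounds is available to size this change, so the expectation is a loose one. Taking compound 2 at 7320 nM as the only number in hand, compound 3 is expected to move toward lower numbers in this assay, by more than the scatter. A second limit remains possible for compound 3. The estimated at least 2.7-fold lower number from compound 1 to compound 3 (0.43 log units; beyond the scatter) rests on that single comparison. The estimate for compound 3 is 12000 nM, with an expected range from 5000 nM to 32500 nM.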

Compound 3, concentration for total growth inhibition: 3350 nM
Compound 3: the middle estimate sits 3.6-fold (0.55 log units) above what was measured, and the stated range ends above it.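

In this assay, among these compounds, hydroxy to methoxy on the 4-chloro-3-hydroxyphenyl group, with the 3-(trifluoromethyl)phenyl group held fixed, gives the first step at this oxygen: an at least 9.7-fold lower number from compound 1 to compound 3 (0.98 log units; beyond the scatter). Going by these compounds, the real size of this step remains unknown and only its lower bound can be read, because compound 1 stands as a limit and not as a number: the limit of > 32500 nM in this assay, at which 1 of the 3 values shown sits. With the 4-chloro-3-methoxyphenyl group kept in place, the group on the amide-type nitrogen also shifts the read-out, as 3-(trifluoromethyl)phenyl in place of 3,4-dichlorophenyl gives a 2.2-fold lower number from compound 2 to compound 3 (0.34 log units; beyond the scatter).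

On these data alone, how an ethoxy group or an amino group would read on this ring in place of the methoxy group remains open, so only one replacement of the hydroxy hydrogen can be judged here. Also open, as far as these compounds go, is whether the step from hydroxy to methoxy holds with 3,4-dichlorophenyl on the amide-type nitrogen, and whether either step carries over to any other cell line or read-out.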